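This account rests on a few compounds, and the source may have more. Where it says the series, first, only, none or still open, it means among the compounds named here.

Compound 2 `CN1CCN(c2nc(-c3cc(Cl)ccc3Cl)nc3[nH]cnc23)CC1` is one of the two compounds measured in an assay on cells for displacement of a labelled ligand from adenosine receptor A1 (Homo sapiens), read by scintillation counting and radioligand binding, with a stated time of 60 min, tested at 10 uM (a lower number here means less inhibition, a higher number more inhibition at the concentration tested (going by the name of the read-out)), and its result is a limit of that assay rather than a number: compound 2 gives > 80%. This is the limit of > 80% in this assay, at which 1 of the 2 values shown sits. Compound 1 `CN1CCN(c2nc(-c3cccc(O)c3)nc3c2ncn3C)CC1`, which carries 3-hydroxyphenyl and a methyl on its core, gives 27.1% in this assay.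

The step to compound 3 `CN1CCN(c2nc(-c3cccc(O)c3)nc3[nH]cnc23)CC1` changes the aromatic group: 3-hydroxyphenyl in place of 2,5-dichlorophenyl on an aromatic carbon. The 2,5-dichlorophenyl that leaves carries no hydrogen-bond donor or acceptor, while the 3-hydroxyphenyl that enters carries one of each. Within the data shown here, no measured step covers this exchange, so the direction can only be expected, not read off. Since compound 1 with 3-hydroxyphenyl gives 27.1%, a fall beyond the usual scatter is expected for compound 3, and the step from compound 2 to compound 3 is estimated as a number at least 38 percentage points lower from compound 2 to compound 3 (beyond the scatter). Compound 3 is therefore expected to give about 42% in this assay, within a range from 15% to 75%.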

Compound 3, a percentage reported as inhibition, at one concentration (the size of the read-out at that concentration, not a potency): > 80%
Compound 3: no number, only a limit; the forecaster's own chance of this, stated with the estimate: 15%; at least 38 percentage points between middle value and limit.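

Compound 3 gives > 80% in this assay as a limit of the assay and not as a number. With 3-hydroxyphenyl kept and hydrogen in place of methyl on an aromatic nitrogen, the comparison shows a number at least 52.9 percentage points higher from compound 1 to compound 3 (beyond the scatter) and so ties a large rise to this single change, which the earlier pair, differing in two places, could not show. The step from 2,5-dichlorophenyl to 3-hydroxyphenyl on the aromatic carbon cannot be read, because both of its ends rest on a limit: the limit of > 80% in this assay, at which 2 of the 3 values shown sit.

On these data alone, how far compound 2 and compound 3 actually lie apart therefore stays open. The compounds shown also leave open how an ethyl group on that aromatic nitrogen, or an amine or a carboxylic acid on the aromatic group, would read.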